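Side-chain change from the low end of the series

A few compounds are considered here, and "the series" means these few. Any claim that something is new, unique, unknown or untested is made for them only; others in the source may bear on it.

In an ADME assay on microsomes from liver (Rattus norvegicus) for metabolic stability, using NADPH, with a stated time of 10 min (on this read-out lower numbers stand for a less stable compound and higher numbers for a more stable compound), compound 2 `NC/C=C/CN(C[C@H]1Cc2ncccc2CN1)[C@H]1CCCc2cccnc21` gives 11%, the lower of the two numbers, and compound 1 `NCCCCN(C[C@H]1Cc2ncccc2CN1)[C@H]1CCCc2cccnc21` gives 64%. Compound 3 `NC(=O)NC/C=C\CN(C[C@H]1Cc2ncccc2CN1)[C@H]1CCCc2cccnc21` differs from compound 2 as follows: a group of 7 heavy atoms (4 carbon, 2 nitrogen, 1 oxygen; no ring) in place of a group of 4 heavy atoms (3 carbon, 1 nitrogen; no ring), on a saturated chain carbon bound to an amine nitrogen. For the measured compounds named here, the one measured step at this place is a number 53 percentage points lower from compound 1 to compound 2 (beyond the scatter), large and beyond the scatter. Going by the values given here, no measured step covers the entering group, so the size remains uncertain. With compound 2 at 11%, little room remains downward, so a moderate rise is expected. The estimated step is a number 19 percentage points higher from compound 2 to compound 3 (beyond the scatter). Compound 3 is expected at 30%, with an estimated range of 10% to 60%.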

Compound 3, percent of the compound remaining: 1%
For compound 3 the middle estimate is 29 percentage points above the measured one; the measured number lies below the stated range.
By their numbers in this assay, from the lowest: compounds 3 and 2 (each within the scatter of the next); then compound 1.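

In this assay, the group of 7 heavy atoms on the chain gives a number 10 percentage points lower from compound 2 to compound 3 (within the scatter), so the larger group does not separate from 3-aminoprop-1-en-1-yl. Measured against the 3-aminopropyl chain, it gives a number 63 percentage points lower from compound 1 to compound 3 (beyond the scatter), which places both chains with a double bond at the low end of these three. Still open, going by these compounds, is whether the group of 7 heavy atoms on a saturated chain would keep the higher number of the 3-aminopropyl chain, and how a carboxylic acid or a longer saturated amine chain would read at this place. No measured evidence accounts for these numbers.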